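Second chloro on the core: compound 2 to compound 3

A few compounds are considered here, and "the series" means these few. Any claim that something is new, unique, unknown or untested is made for them only; others in the source may bear on it.

The two measured compounds share one core and differ only in the placement of the chloromethyl group on the pendant ring. Compound 1 `ClCc1ccccc1Cn1cnc2c(Cl)ncnc21` is the stronger of the pair: in a functional assay on OVCAR-8 cells (Homo sapiens) for cytotoxicity, read by sulforhodamine B assay, with a stated time of 48 h (a lower number here means a stronger inhibitor of growth, a higher number a weaker inhibitor of growth), compound 1 gives 5240 nM. Compound 2 `ClCc1cccc(Cn2cnc3c(Cl)ncnc32)c1` is the weaker: in this assay compound 2 gives 41700 nM. Within the data shown here, compound 2 therefore holds the highest of the two numbers, and its distance from compound 1 lies beyond the scatter; no single-point step is defined between them, so the two values are read side by side.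

Compound 3 `ClCc1cccc(Cn2cnc3c(Cl)nc(Cl)nc32)c1` keeps the arm of compound 2 and alters the core: chloro in place of hydrogen on an aromatic carbon, between two ring nitrogen atoms, meta to a chloro group, meta to a fused ring and para to a fused ring. Among the measured compounds shown here, no measured pair shows this change, so its size and direction are open. The step of a 1.4-fold lower number from compound 2 to compound 3 (0.14 log units; within the scatter) is expected to stay within the scatter or only modestly beyond it, with no strong lean either way. Compound 3 is therefore estimated at 30000 nM, with a range from 8000 nM to 110000 nM.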

Compound 3, concentration for total growth inhibition: 3540 nM
Estimate against measurement, compound 3: 8.5-fold (0.93 log units) above; the whole stated range lies above it.
By their numbers in this assay, from the lowest: compounds 3 and 1 (each within the scatter of the next); then compound 2.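

The aromatic carbon between two ring nitrogen atoms on the shared core is a sensitive position: in this assay, chloro in place of hydrogen there gives a 12-fold lower number from compound 2 to compound 3 (1.07 log units; beyond the scatter), a large step beyond the scatter. Among these compounds, compound 1 and compound 2 differ only on the arm, so this is the first step to show that a single change on the core, with the arm held constant, can move the number by this much. No supporting data bear on what lies behind this step.

The chloro change is shown with one arm only, that of compound 2, so whether a step of this size carries over to the arm of compound 1 remains open. Also open, on these data alone, is whether the step belongs to chloro specifically or extends to other groups on the same carbon, such as fluoro, methoxy or an amine.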